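Replacing phenyl with isopropyl: what to expect

This account rests on a few compounds, and the source may have more. Where it says the series, first, only, none or still open, it means among the compounds named here.

Within the data shown here, in a functional assay on HCT-116 cells (Homo sapiens) for cytotoxicity, read by MTT assay, with a stated time of 48 h, in the presence of a further agent that is not named here (a lower number here means that less compound is needed, a higher number that more compound is needed for the effect), compound 1 `Cn1nc(C(F)(F)F)c2c(-c3ccccc3)cc(NNC(=O)Nc3cc(Cl)nc(Cl)c3)nc21` gives 18100 nM and holds the higher of the two numbers so far, while compound 2 `Cn1ncc2c(-c3ccccc3)cc(NNC(=O)Nc3cc(Cl)nc(Cl)c3)nc21` gives 6240 nM there. Compound 3 `CC(C)c1cc(NNC(=O)Nc2cc(Cl)nc(Cl)c2)nc2c1c(C(F)(F)F)nn2C` has isopropyl in place of phenyl on an aromatic carbon and has not yet been measured. Among the measured compounds shown here, the only measured step is a 2.9-fold lower number from compound 1 to compound 2 (0.46 log units; beyond the scatter) and it concerns trifluoromethyl, not phenyl, so no measurement tests this change and its direction stays open. A small change is expected, estimated as a 1.2-fold lower number from compound 1 to compound 3 (0.08 log units; within the scatter) for now. Compound 3 is expected near 15000 nM within a range from 6000 nM to 40000 nM on this estimate.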

Compound 3, half-maximal effective concentration: 27200 nM
Beside the measured number, compound 3's estimate is 1.8-fold (0.26 log units) below it; the range from low to high includes it.
By their numbers in this assay, from the lowest: compound 2; then compounds 1 and 3 (each within the scatter of the next).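

Isopropyl in place of phenyl gives a 1.5-fold higher number from compound 1 to compound 3 (0.18 log units; within the scatter) in this assay. Among these compounds, this is the first measurement at this position, and it shows that a ring of carbon only can give way to a smaller open group with no change that stands clear of the scatter. No measured property bears on this result.

From the compounds shown here alone, it remains open whether the same swap would behave alike on the core without trifluoromethyl. Also open, going by these compounds, is what an amine, a carboxylic acid or a longer chain would do on this aromatic carbon.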